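The source may report more compounds than this note shows. Statements on the series, on what has been measured and on what is new or still open speak of the compounds shown alone.

In a functional assay on FM3A cells (Mus musculus) for antiproliferative activity, read by cell counting, with a stated time of 2 days (a higher number here means a weaker inhibitor, a lower number a stronger inhibitor), compound 1 `COc1ccc(C(=O)c2sc(Nc3ccccc3)nc2N)cc1OC` gives > 10000 nM, which is a limit of the assay and not a number. That reading is the limit of > 10000 nM in this assay, at which 1 of the 2 values shown sits. Compound 2 `COc1ccc(Nc2nc(N)c(C(=O)c3ccc(OC)c(OC)c3)s2)cc1` gives 71 nM in this assay. Among the measured compounds shown here, the only measured step, an at least 140-fold lower number from compound 1 to compound 2 (2.14 log units; beyond the scatter), is large and is methoxy in place of hydrogen on an aromatic carbon. Compound 3 `COc1cccc(C(=O)c2sc(Nc3ccccc3)nc2N)c1` differs from compound 1 by hydrogen in place of methoxy on an aromatic carbon, ortho to a methoxy group and para to a large group. This exchange runs the other way and at a different place, so the measured step bears on it only loosely. No clear gain is expected, and no readable step beyond the scatter. For compound 3 the expected value is 10000 nM, with an estimated range from 2500 nM to 30000 nM. The estimated step is a number no higher from compound 1 to compound 3 (the limit leaves the size open).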

Compound 3, half-maximal inhibitory concentration: 6200 nM
For compound 3 the middle estimate is 1.6-fold (0.21 log units) above the measured one, within the range that was stated.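

In this assay, hydrogen in place of methoxy gives an at least 1.6-fold lower number from compound 1 to compound 3 (0.20 log units; that floor lies within the scatter), so the methoxy group para to a large group can leave the core without any loss of activity. Unlike compound 1, compound 3 gives a number, which provides a measured point of reference for further changes at this position. The step remains only a floor, and no gain can be claimed, because compound 1 stands at a limit of the assay: the limit of > 10000 nM in this assay, at which 1 of the 3 values shown sits.

The compounds shown leave open whether another group at this position, such as a hydroxyl, an amine or a fluorine atom, would change the value beyond the scatter. They also leave open how the same exchange would read on compound 2, where no limit stands in the way.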